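A few compounds are considered here, and "the series" means these few. Any claim that something is new, unique, unknown or untested is made for them only; others in the source may bear on it.

Compound 1 `CN(C)C(=O)c1cc2cnc(Nc3ccc(NC(=O)C4(C(=O)Nc5ccc(Cl)cc5)CC4)cc3)nc2n1C1CCCC1` gives 52.2% in a functional assay on NCI-H1299 cells (Homo sapiens) for inhibition, read by CCK-8 assay, with a stated time of 72 h, tested at 1 uM; a lower number here means less inhibition of growth, a higher number more inhibition of growth at the concentration tested.
Compound 2 `CN(C)C(=O)c1cc2cnc(Nc3ccc(NC(=O)C4(C(=O)Nc5cccc(Cl)c5)CC4)cc3)nc2n1C1CCCC1` gives 47.9% in this assay.
Compound 3 `CN(C)C(=O)c1cc2cnc(Nc3ccc(NC(=O)C4(C(=O)Nc5ccc(Cl)c(C(F)(F)F)c5)CC4)cc3)nc2n1C1CCCC1` gives 39.5% in this assay.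

Compound 1 has the highest of the three numbers in this assay, but compound 2 sits within the scatter of it; only compound 3 lies beyond it. Compound 4 `CN(C)C(=O)c1cc2cnc(Nc3ccc(NC(=O)C4(C(=O)Nc5cccc(Br)c5)CC4)cc3)nc2n1C1CCCC1` differs from compound 1 in one place: 3-bromophenyl in place of 4-chlorophenyl on an amide-type nitrogen. Going by the values given here, the only measured step that bears on this is a number 4.3 percentage points lower from compound 1 to compound 2 (within the scatter), which replaced 4-chlorophenyl with 3-chlorophenyl, the nearest analogue of the 3-bromophenyl in compound 4. Among the compounds with values here, no measured step exchanges chlorine for bromine, so that part of the change is untested. The expected step is therefore small, a number 5.2 percentage points lower from compound 1 to compound 4 (within the scatter), and not beyond the scatter. Compound 4 is estimated to give 47%, with a range from 35% to 59%.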

Compound 4, percent growth inhibition at one concentration: 46.6%
Compound 4: the middle estimate sits 0.4 percentage points above what was measured, and the stated range covers the measured number.
By their numbers in this assay, from the lowest: compounds 3, 4, 2 and 1 (each within the scatter of the next, the first and the last beyond it).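

In this assay, bromo in place of chloro on the aromatic carbon of the group on the amide-type nitrogen gives the first halogen exchange seen here (a number 1.3 percentage points lower from compound 2 to compound 4 (within the scatter)). The 3-bromophenyl group also cannot be told apart from 4-chlorophenyl (a number 5.6 percentage points lower from compound 1 to compound 4 (within the scatter)) or from 4-chloro-3-(trifluoromethyl)phenyl (a number 7.1 percentage points higher from compound 3 to compound 4 (within the scatter)). Compound 4 therefore adds no step beyond the scatter at this position.

From the compounds shown here alone, whether an amine or a carboxylic acid on this phenyl ring would move the number further remains open. The data shown offer no measurement that explains these small steps.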